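Swapping 4-Chlorophenyl for Furan on the Shared Core

The compounds below may be only part of what the source reports. "The series", "measured", "known", "first", "only" and "open" are said of these compounds alone.

Of the compounds shown here, three on one shared core have been measured in an assay on cells for displacement of a labelled ligand from adenosine receptor A1 (Homo sapiens), read by scintillation counting, with a stated time of 120 min, tested at 1 uM; a higher number here means more inhibition at the concentration tested (going by the name of the read-out), a lower number less inhibition. Compound 1 `Nc1nccn2cc(-c3ccccc3)nc12` carries hydrogen at the varied position, and in this assay compound 1 gives 30%. Compound 2 `COc1ccc(-c2cn3cc(-c4ccccc4)nc3c(N)n2)cc1` carries 4-methoxyphenyl there, and compound 2 gives 20%. Compound 3 `Nc1nc(-c2ccc(Cl)cc2)cn2cc(-c3ccccc3)nc12` carries 4-chlorophenyl there, and compound 3 gives 3%, the lowest of the three numbers; its nearest neighbour is compound 2, and compound 1 is furthest from it.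

The measured steps show how this position behaves. Adding 4-methoxyphenyl gave a number 10 percentage points lower from compound 1 to compound 2 (within the scatter). Adding 4-chlorophenyl gave a number 27 percentage points lower from compound 1 to compound 3 (beyond the scatter). Exchanging the substituent on that aryl ring gave a number 17 percentage points lower from compound 2 to compound 3 (beyond the scatter).

Compound 4 `Nc1nc(-c2ccco2)cn2cc(-c3ccccc3)nc12` is not yet measured. It differs from compound 3 in one place: furan-2-yl in place of 4-chlorophenyl on an aromatic carbon. Going by the values given here, no measured step involves furan-2-yl, so the expectation rests on the span of the measured compounds. Compound 1, with hydrogen here, gave 30%. Compound 3, with 4-chlorophenyl, gave 3%. A five-membered ring with one hetero atom is expected to land between these, so for compound 4 the expected step is a number 12 percentage points higher from compound 3 to compound 4 (beyond the scatter). Compound 4 is therefore estimated at 15%, with a range from 0% to 35%.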

Compound 4, a percentage reported as inhibition, at one concentration (the size of the read-out at that concentration, not a potency): 28%
Estimate against measurement, compound 4: 13 percentage points below; low and high end bracket the measured number.
By their numbers in this assay, from the lowest: compound 3; then compounds 2, 4 and 1 (each within the scatter of the next).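

In this assay an aromatic ring at this position does not by itself bring the number down: replacing 4-chlorophenyl with furan-2-yl gives a number 25 percentage points higher from compound 3 to compound 4 (beyond the scatter) and replacing hydrogen with furan-2-yl gives a number 2 percentage points lower from compound 1 to compound 4 (within the scatter) so the furan-2-yl compound cannot be told apart from the compound with no ring here at all. Against the other six-membered aryl group, the exchange gives a number 8 percentage points higher from compound 2 to compound 4 (within the scatter) which leaves compound 3 as the only one of the four separated from all the others beyond the scatter, so among these compounds the clear drop belongs to 4-chlorophenyl and not to aryl groups in general. Nothing available explains why furan-2-yl and 4-chlorophenyl behave differently here.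

These compounds change ring size, ring oxygen and the group on the ring together, so the contribution of each cannot be separated, and a plain phenyl or a thiophen-2-yl group at this position would be the direct comparison. All four numbers are also readings at one concentration, so how a saturated amine such as morpholine would fare here remains open, as does the size of the effect of the compounds shown at any other concentration.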